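A few compounds are considered here, and "the series" means these few. Any claim that something is new, unique, unknown or untested is made for them only; others in the source may bear on it.

Measured so far:
Compound 1, `CCOC(=O)C1=Cc2ccccc2OC1(OCc1cc(-c2ccc(F)cc2F)no1)C(F)(F)F` — in a functional assay on DU-145 cells (Homo sapiens) for inhibition, read by MTT assay, with a stated time of 24 h (a lower number here means a stronger inhibitor, a higher number a weaker inhibitor), compound 1 reaches only a limit of the assay, > 150000 nM.
Compound 2, `CCOC(=O)C1=Cc2ccccc2OC1(OCc1cn(CC(=O)Nc2cccc(Cl)c2)nn1)C(F)(F)F` — in this assay compound 2 gives 10100 nM.

For the measured compounds named here, compound 2 therefore stands as the only compound with a true number in this assay; the other value shown is a limit, (the limit of > 150000 nM in this assay, at which 1 of the 2 values shown sits). Compound 3, `CCOC(=O)C1=Cc2ccccc2OC1(OCc1cn(CC(=O)Nc2cccc(F)c2)nn1)C(F)(F)F`, has not yet been measured. It differs from compound 2 in one place: fluoro in place of chloro on an aromatic carbon, that is 3-chlorophenyl to 3-fluorophenyl. Going by the values given here, no step between two measured compounds is available to calibrate such an exchange. The exchange is expected to shift this assay only a little, most likely toward a slightly weaker inhibitor, and for compound 3 the expected step is a 1.5-fold higher number from compound 2 to compound 3 (0.17 log units; within the scatter), which may not exceed the scatter. Compound 3 is thus expected to give about 15000 nM in this assay, within a range of 5000 nM to 50000 nM.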

Compound 3, half-maximal inhibitory concentration: > 150000 nM
Compound 3 gave a limit, no number; the forecaster's own chance of this, stated with the estimate: 15%; middle value at least 10-fold (1.00 log units) from the limit.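

In this assay the exchange of chloro for fluoro on this aromatic carbon proves to be no small change, with an at least 14-fold higher number from compound 2 to compound 3 (1.17 log units; beyond the scatter) as its step. Compound 3 gives > 150000 nM as a limit of the assay and not a number, so the full size of the step cannot be read: the limit of > 150000 nM in this assay, at which 2 of the 3 values shown sit.

Earlier, nothing showed that this single position mattered; now the measurable value of compound 2 is seen to depend on the chloro, since a fluoro in its place, with all else unchanged, does not keep a measurable value. The compounds shown leave open whether a bromo, a methyl or a methoxy on the same carbon would keep a measurable value. They also leave open whether an unsubstituted phenyl would fall at the limit too.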